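The source may report more compounds than this note shows. Statements on the series, on what has been measured and on what is new or still open speak of the compounds shown alone.

Compound 1 `COc1ccc(OC)c(/C=N/NC(=O)Nc2ccc(Oc3ccnc(-c4nncn4CCN(C)C)c3)c(F)c2)c1` gives 1950 nM in a functional assay on A549 cells (Homo sapiens) for cytotoxicity, read by MTT assay, with a stated time of 72 h; a higher number here means a weaker inhibitor, a lower number a stronger inhibitor. Among the compounds with values here, compound 2 `CN(C)CCn1cnnc1-c1cc(Oc2ccc(NC(=O)N/N=C/c3cccc(Cl)c3Cl)cc2F)ccn1` gives 1090 nM in this assay, and the one step between these two, a 1.8-fold lower number from compound 1 to compound 2 (0.25 log units; within the scatter), keeps compound 2 within the scatter of compound 1, so the two numbers are not to be told apart on this evidence. Compound 3 `COc1cc(/C=N/NC(=O)Nc2ccc(Oc3ccnc(-c4nncn4CCN(C)C)c3)c(F)c2)ccc1O` is to be measured in this assay. Its change from compound 2 is 4-hydroxy-3-methoxyphenyl in place of 2,3-dichlorophenyl on a carbon with a double bond to nitrogen. Within the data shown here, the only step recorded at this carbon with a double bond to nitrogen is the one from compound 1 to compound 2, which was within the scatter, and no measured pair bears on a 4-hydroxy-3-methoxyphenyl group. The expectation for this assay is therefore a step of a 1.4-fold higher number from compound 2 to compound 3 (0.14 log units; within the scatter), that is, nothing beyond the scatter, in either direction. On that basis compound 3 is estimated at 1500 nM, with a range of 500 nM to 5000 nM.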

Compound 3, half-maximal inhibitory concentration: > 100000 nM
Compound 3 ended at the assay's limit; the forecaster's own chance of this, stated with the estimate: 5%; middle value at least 66-fold (1.82 log units) away from the limit.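

Compound 3 is read only as a limit of the assay, not as a number: the limit of > 100000 nM in this assay, at which 1 of the 3 values shown sits. The carbon with a double bond to nitrogen was not shown to be sensitive by a 1.8-fold lower number from compound 1 to compound 2 (0.25 log units; within the scatter), but in this assay the aryl group there clearly matters, with an at least 91-fold higher number from compound 2 to compound 3 (1.96 log units; beyond the scatter) and an at least 51-fold higher number from compound 1 to compound 3 (1.70 log units; beyond the scatter). The entering 4-hydroxy-3-methoxyphenyl has 1 hydrogen-bond donor and 2 hydrogen-bond acceptors, against 0 of each for the leaving 2,3-dichlorophenyl, but this count alone assigns no cause.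

The compounds shown do not separate the contribution of the hydroxy group from that of the methoxy group within 4-hydroxy-3-methoxyphenyl. Going by these compounds, how a phenyl carrying only a hydroxy group, or one carrying an amine or a carboxylic acid, would read at this carbon remains open.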